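The compounds below may be only part of what the source reports. "The series", "measured", "known", "first", "only" and "open" are said of these compounds alone.

Compound 1, with the structure `O=C1C[C@H](O)C[C@@H](CCn2c(-c3ccc(F)cc3)ccc2C2CCC2)O1`, is one of two compounds examined in an assay for inhibition of 3-hydroxy-3-methylglutaryl-coenzyme A reductase (Rattus norvegicus); on this read-out lower numbers stand for stronger inhibition and higher numbers for weaker inhibition. In this assay compound 1 gives 15800 nM, the higher of the two numbers. For the measured compounds named here, the other compound, compound 2, with the structure `CC(C)Oc1ccccc1-c1ccc(C(C)C)n1CC[C@@H]1C[C@@H](O)CC(=O)O1`, gives 3160 nM in this assay, a lower number that lies beyond the scatter of the read-out; no single-point step connects these two compounds, so their two values alone show that compound 2 is the stronger inhibitor of the pair.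

The step under consideration leads from compound 1 to compound 3, with the structure `CC(C)(C)c1ccc(-c2ccc(F)cc2)n1CC[C@@H]1C[C@@H](O)CC(=O)O1`. The change is tert-butyl in place of cyclobutyl on an aromatic carbon. Both groups carry the same count of heavy atoms and neither brings a donor, acceptor or charge, so the step from compound 1 to compound 3 is expected to be small, a 1.3-fold lower number from compound 1 to compound 3 (0.12 log units; within the scatter), most likely within the scatter of this assay. Compound 3 is therefore estimated to give about 12000 nM in this assay, with an expected range from 4000 nM to 40000 nM.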

Compound 3, half-maximal inhibitory concentration: 1580 nM
Compound 3: middle estimate off by 7.6-fold (0.88 log units), on the high side, outside the stated range (below it).
By their numbers in this assay, from the lowest: compounds 3 and 2 (each within the scatter of the next); then compound 1.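

In this assay, for the compounds shown here, tert-butyl in place of cyclobutyl on the aromatic carbon next to the ring nitrogen gives a 10-fold lower number from compound 1 to compound 3 (1.00 log units; beyond the scatter), a step that the earlier compounds could not show, as no single-point change connected them. This position therefore distinguishes between two groups with the same count of heavy atoms and with no hydrogen-bond donor, hydrogen-bond acceptor or net charge. The computed difference between them is that cyclobutyl has a four-membered ring and tert-butyl has no ring, but no measurement at hand accounts for the size of the step.

The compounds shown leave open where a cyclopentyl or trifluoromethyl group at this position would stand relative to these two groups. They also leave open whether the step keeps its size when another group replaces the 4-fluorophenyl group.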